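Ethyl in place of hydrogen on compound 3

This account rests on a few compounds, and the source may have more. Where it says the series, first, only, none or still open, it means among the compounds named here.

- compound 1 (`O=c1ccc2cc(Oc3ccc(Cl)cc3O)ccc2o1`) gives 96200 nM
- compound 2 (`CCc1cc(=O)oc2ccc(Oc3ccc(Cl)cc3O)cc12`) gives 142000 nM
- compound 3 (`O=c1ccc2ccc(Oc3ccc(Cl)cc3O)cc2o1`) gives 188000 nM

These values come from an ADME assay on L6 cells (Rattus norvegicus) for inhibition, read by fluorescence, with a stated time of 72 h (on this read-out lower numbers stand for stronger inhibition and higher numbers for weaker inhibition), and do not separate into an order. Compound 3 lies within the scatter of both compound 1 and compound 2.

Compound 4 (`CCc1cc(=O)oc2cc(Oc3ccc(Cl)cc3O)ccc12`) is compound 3 with ethyl in place of hydrogen on an aromatic carbon, on the six-membered aromatic ring with 1 oxygen, opposite the ring oxygen.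

Within the data shown here, one measured step bears on this change, the same exchange made on compound 1. It gives a 1.5-fold higher number from compound 1 to compound 2 (0.17 log units; within the scatter) and thus stays within the scatter. This is a single pair on a different parent, and the exchange has not yet been measured on compound 3 itself. No step beyond the scatter is therefore expected in this assay for this change, with only a slight lean towards a higher number, as in that one pair.

The estimated step is a 1.2-fold higher number from compound 3 to compound 4 (0.07 log units; within the scatter) and is expected to remain within the scatter. The expected value for compound 4 is 220000 nM in an estimated range from 110000 nM to 420000 nM for the measurement still to come.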

Compound 4, half-maximal inhibitory concentration: 84800 nM
Compound 4: middle estimate off by 2.6-fold (0.41 log units), on the high side; measured number below the stated range.
By their numbers in this assay, from the lowest: compounds 4, 1, 2 and 3 (each within the scatter of the next, the first and the last beyond it).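

In this assay, among these compounds, ethyl in place of hydrogen on an aromatic carbon, opposite the ring oxygen, gives a 2.2-fold lower number from compound 3 to compound 4 (0.35 log units; beyond the scatter), a modest change and the only step of this exchange that lies beyond the scatter. The exchange therefore does not carry one size or direction from one core to the other: the same change on two cores in this assay, a 1.5-fold higher number (0.17 log units; within the scatter) from compound 1 to compound 2 and a 2.2-fold lower number (0.35 log units; beyond the scatter) from compound 3 to compound 4, 3.3-fold (0.51 log units) apart, beyond the scatter of two such steps On these two pairs alone, the outcome of placing ethyl on an aromatic carbon depends on the core that receives it, and the pair of compound 1 and compound 2, which stays within the scatter, goes against any general rule that ethyl lowers the number.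

The compounds shown hold only hydrogen or ethyl at this position, so it remains open whether the lower number for compound 4 is specific to ethyl or extends to methyl or a longer chain such as propyl. Also open, on these data alone, is whether the gap between the two cores persists with a different kind of group at this position, such as an amine or a carboxylic acid.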